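The compounds below may be only part of what the source reports. "The series", "measured", "known", "first", "only" and "open" are said of these compounds alone.

Of the compounds shown here, three have been measured in a physicochemical assay for solubility (a higher number here means a more soluble compound, a lower number a less soluble compound), and none of them yields a number. Compound 1 (`CNC(=O)c1cc(C(=O)NC2CCOCC2)cn(Cc2ccccc2)c1=O`) gives >= 174 ug/mL, which is a limit of the assay. Compound 2 (`CNC(=O)c1cc(C(=O)NC2CC2)cn(CC2CCCCC2)c1=O`) gives >= 148 ug/mL, also a limit. Compound 3 (`CNC(=O)c1cc(C(=O)NC2CC2)cn(Cc2cccc3[nH]c(C)nc23)c1=O`) gives >= 198 ug/mL, again a limit. Compound 1 therefore has no exact value, and it cannot be ranked against the other two. For the measured compounds named here, no pair of measured compounds differs in only one place, so the data contain no measured step to serve as a guide.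

The next compound, compound 4 (`CNC(=O)c1cc(C(=O)NCCC(C)C)cn(Cc2ccccc2)c1=O`), keeps the core of compound 1 and changes only the amide substituent. It carries isopentyl in place of oxan-4-yl on an amide-type nitrogen. Going by the values given here, with no measured step to scale this change, the expectation is necessarily a rough one. A moderate fall in this assay, somewhat beyond the usual scatter, is expected, and the estimated size is an at least 2.3-fold lower number from compound 1 to compound 4 (0.36 log units; beyond the scatter). The chance remains that the result will again be only a limit. For compound 4 the expected value is 75 ug/mL, with an estimated range from 25 ug/mL to 190 ug/mL.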

Compound 4, solubility: 10 ug/mL
For compound 4 the middle estimate is 7.5-fold (0.88 log units) above the measured one; measured number outside the range, below it.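

For the compounds shown here, the swap at this amide substituent is the only measured step, and in this assay isopentyl in place of oxan-4-yl on an amide-type nitrogen gives an at least 17-fold lower number from compound 1 to compound 4 (1.24 log units; beyond the scatter). The earlier compounds shown here all stood at limits and could not show whether this position matters, whereas this large step shows that a single change here, with the rest of the core of compound 1 kept, is enough to bring the read-out down from the limit to an exact number. The step is itself only a bound, because compound 1 rests on a limit of the assay, and its true size could be larger: the limit of >= 174 ug/mL in this assay, at which 1 of the 4 values shown sits.

The change removes both the ring and its oxygen, and the compounds shown do not separate the two; a cyclohexyl group would keep the ring without the oxygen, and a methoxypropyl chain would keep an oxygen without the ring. Nor do they show what a shorter chain, or an amine at the end of the chain, would give at this position.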